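Changing the nitrogen substituent of compound 2

This account rests on a few compounds, and the source may have more. Where it says the series, first, only, none or still open, it means among the compounds named here.

In a functional assay on MCF7 cells (Homo sapiens) for cytotoxicity, read by MTT assay, with a stated time of 96 h (a higher number here means a weaker inhibitor, a lower number a stronger inhibitor), compound 1 `COc1cc(C(=O)c2cn(-c3cccc(N)c3)cc2-c2ccccc2[N+](=O)[O-])cc(OC)c1OC` gives 14 nM and compound 3 `COc1cc(C(=O)c2cn(-c3cccc(N)c3)cc2-c2ccc(N)cc2)cc(OC)c1OC` gives 14 nM, which is no change at the digits printed from compound 1 to compound 3 (within the scatter). Compound 2 `COc1cc(C(=O)c2cn(-c3cccc(N)c3)cc2-c2cccc(N)c2)cc(OC)c1OC` gives 60 nM, the highest number of the three. The steps that separate it from the other two are a 4.3-fold higher number from compound 1 to compound 2 (0.63 log units; beyond the scatter) and a 4.3-fold lower number from compound 2 to compound 3 (0.63 log units; beyond the scatter).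

Compound 4 `COc1cc(C(=O)c2cn(-c3ccc(F)cc3)cc2-c2cccc(N)c2)cc(OC)c1OC` keeps the rest of compound 2 but carries 4-fluorophenyl in place of 3-aminophenyl on an aromatic nitrogen. All three measured steps change the group on an aromatic carbon, and none changes the group on the aromatic nitrogen. They therefore offer only a rough guide to size, and the data give no direction. The modest 4.3-fold higher number from compound 1 to compound 2 (0.63 log units; beyond the scatter) suggests that a single aryl exchange in this series can move the number noticeably, so a step of about that size in either direction remains possible in this assay. The expected central step is small, namely a 1.3-fold lower number from compound 2 to compound 4 (0.12 log units; within the scatter), which lies within the scatter. For compound 4, the estimated value is 45 nM, with an expected range from 10 nM to 200 nM.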

Compound 4, half-maximal inhibitory concentration: 53 nM
Compound 4: middle estimate off by 1.2-fold (0.07 log units), on the low side; the range from low to high includes it.
By their numbers in this assay, from the lowest: compounds 1 and 3 (each within the scatter of the next); then compounds 4 and 2 (each within the scatter of the next).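

In this assay, the only change shown on the aromatic nitrogen gives a 1.1-fold lower number from compound 2 to compound 4 (0.05 log units; within the scatter), which is within the scatter, whereas two of the three steps on the aromatic carbon were beyond it. For this pair, then, the group on the nitrogen can go from 3-aminophenyl to 4-fluorophenyl, losing the hydrogen-bond donor and acceptor counted for the former, with no change in the number that can be distinguished from the scatter. Nothing measured here explains why the number responds so little at this position.

Going by these compounds, compound 4 keeps the 3-aminophenyl group on the aromatic carbon, so it remains open whether the same exchange would read alike with the other aryl groups there. Also open, on these data alone, is how a smaller nitrogen group, such as a methyl, or a carboxylic acid on the nitrogen's aryl ring would read.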